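The source may hold more compounds than are shown below. What is called first, only, known or untested is meant among the compounds shown, and "the series" means these compounds.

Measured compounds in an ADME assay on cells (Homo sapiens) for cytotoxicity, read by polymerase chain reaction, with a stated time of 3 days; a lower number here means that less compound is tolerated, a higher number that more compound is tolerated:
compound 1 `Cc1nc(NCCNC(=O)NC(C)(C)C)nc(N[C@@H]2C[C@H](CO)[C@@H](O)[C@H]2O)c1-c1nc2ccccc2s1` gives > 25000 nM, which is a limit of the assay and not a number.
compound 2 `Cc1nc(NCCC(F)(F)F)nc(N[C@@H]2C[C@H](CO)[C@@H](O)[C@H]2O)c1-c1nc2ccccc2s1` gives 9000 nM.

Compound 2 thus holds the only number shown in this assay; the one other value is a limit. Among the measured compounds shown here, the single measured step, an at least 2.7-fold lower number from compound 1 to compound 2 (0.44 log units; beyond the scatter), changes a saturated chain substituent on the same ring nitrogen, and its size is bounded only at one end by the limit of > 25000 nM in this assay, at which 1 of the 2 values shown sits. Compound 3 `Cc1nc(Nc2nccs2)nc(N[C@@H]2C[C@H](CO)[C@@H](O)[C@H]2O)c1-c1nc2ccccc2s1` differs from compound 2 by 1,3-thiazol-2-yl in place of 3,3,3-trifluoropropyl on a nitrogen on an aromatic ring. For the measured compounds named here, no measured step swaps a chain for an aromatic ring at this position, so the one step bears on it only in showing that a change here moved the read-out beyond the scatter. A shift of the order a 1.8-fold lower number from compound 2 to compound 3 (0.26 log units; within the scatter) is expected, with wide uncertainty in either direction. For compound 3 the estimated value in this assay is 5000 nM, range 1500 nM to 20000 nM.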

Compound 3, half-maximal cytotoxic concentration: 15000 nM
Compound 3: middle estimate off by 3.0-fold (0.48 log units), on the low side; the measured number falls inside the stated range.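

In this assay, a five-membered aromatic ring on this nitrogen is not told apart from the saturated chain: a 1.7-fold higher number from compound 2 to compound 3 (0.22 log units; within the scatter). Among the compounds shown here, the earlier step covered only a change from one chain to another, so this is the first sign that 1,3-thiazol-2-yl can replace 3,3,3-trifluoropropyl with the read-out staying within the scatter, while an at least 1.6-fold lower number from compound 1 to compound 3 (0.22 log units; that floor lies within the scatter) gives only a floor and does not separate these two compounds. The value of compound 1 is a limit and not a number, so that step is bounded at one end only: the limit of > 25000 nM in this assay, at which 1 of the 3 values shown sits.

Still open, on these data alone, is how a pyridin-2-yl group, a primary amine or a carboxylic acid at the end of the chain would read here. With so few compounds, one aromatic ring and two chains set no trend for this position.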